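A Nitrile-Bearing Pyridyl Group on the Shared Core

The compounds below may be only part of what the source reports. "The series", "measured", "known", "first", "only" and "open" are said of these compounds alone.

Compound 2 `Nc1nc(-c2ccncc2)nc2sc(Cc3ccccc3)cc12` is one of a pair of analogues that share one core and differ only in the aryl group sitting between two ring nitrogen atoms. In a functional assay on CHO-K1 cells for antagonist activity at adenosine receptor A1 (Homo sapiens), read by a beta-galactosidase reporter and cAMP accumulation, with stated times of 15 min and 6 h (on this read-out lower numbers stand for stronger inhibition and higher numbers for weaker inhibition), compound 2 gives 812 nM. Compound 1 `Nc1nc(-c2ccc(C3CC3)o2)nc2sc(Cc3ccccc3)cc12` carries 5-cyclopropylfuran-2-yl at that place and gives 861 nM in this assay; the step of a 1.1-fold lower number from compound 1 to compound 2 (0.03 log units; within the scatter) shows that exchanging this aryl group left the number within the scatter, so compound 2 stands together with compound 1 on the numbers shown. Compound 3 `N#Cc1cncc(-c2nc(N)c3cc(Cc4ccccc4)sc3n2)c1` has not yet been measured in this assay. It differs from compound 2 by 5-cyanopyridin-3-yl in place of pyridin-4-yl on an aromatic carbon. For the measured compounds named here, no measured step covers this exact change; the only comparison at hand, a 1.1-fold lower number from compound 1 to compound 2 (0.03 log units; within the scatter), concerned the same place and stayed within the scatter. The step of a 1.2-fold lower number from compound 2 to compound 3 (0.06 log units; within the scatter) is therefore the estimated change, small and with no clear direction. For compound 3 the expected value in this assay is 700 nM, within a range from 250 nM to 2500 nM.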

Compound 3, inhibition constant: 1160 nM
Compound 3: the middle estimate sits 1.7-fold (0.22 log units) below what was measured; the measured number falls inside the stated range.
By their numbers in this assay, from the lowest: compounds 2, 1 and 3 (each within the scatter of the next).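

Replacing pyridin-4-yl with 5-cyanopyridin-3-yl at the place between two ring nitrogen atoms gives in this assay a 1.4-fold higher number from compound 2 to compound 3 (0.15 log units; within the scatter) and, against the other aryl group, a 1.3-fold higher number from compound 1 to compound 3 (0.13 log units; within the scatter). The earlier pair had shown this tolerance only for pyridin-4-yl and 5-cyclopropylfuran-2-yl, whereas compound 3 extends it to a larger group with a nitrile, holding 8 heavy atoms and 2 hydrogen-bond acceptors. Nothing available explains why the numbers of all three compounds stay within the scatter.

Compound 3 alters both the nitrile and the ring attachment at once, so the compounds shown cannot separate these two changes; plain pyridin-3-yl would do so. They also leave open whether a non-aromatic group at this place, such as an amine or a carboxylic acid, would move the number beyond the scatter.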